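A Methyl Added to Compound 2

This account rests on a few compounds, and the source may have more. Where it says the series, first, only, none or still open, it means among the compounds named here.

- compound 1 `CCOC(=O)c1sc2cccc(C)c2c1Nc1cc(OC)c(OC)c(OC)c1` gives 2520 nM
- compound 2 `COC(=O)c1sc2ccccc2c1Nc1cc(OC)c(OC)c(OC)c1` gives 427 nM

In a functional assay on HeLa cells (Homo sapiens) for cytotoxicity, read by MTT assay, with a stated time of 72 h (a lower number here means a stronger inhibitor, a higher number a weaker inhibitor), compound 2 has the lower number of the two, and its gap to compound 1 lies beyond the usual scatter. Compound 3 `COC(=O)c1sc2cccc(C)c2c1Nc1cc(OC)c(OC)c(OC)c1` has not been measured yet. It differs from compound 2 by a single change, methyl in place of hydrogen on an aromatic carbon and nothing else. Compound 1 also carries that methyl and gives 2520 nM but it differs from compound 2 in a second place too, so its value is only a rough guide. A weaker result is therefore expected, with a higher number beyond the scatter, and the estimated change is a 2.6-fold higher number from compound 2 to compound 3 (0.41 log units; beyond the scatter) in this assay as a best guess. The estimate for compound 3 is 1100 nM (expected range 350 nM to 3500 nM).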

Compound 3, half-maximal inhibitory concentration: 1300 nM
Compound 3: the middle estimate sits 1.2-fold (0.07 log units) below what was measured, and the stated range covers the measured number.
By their numbers in this assay, from the lowest: compound 2; then compounds 3 and 1 (each within the scatter of the next).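

In this assay, going by these compounds alone, the single change of hydrogen to methyl on the aromatic carbon gives a 3.0-fold higher number from compound 2 to compound 3 (0.48 log units; beyond the scatter) with nothing else altered, so this methyl's effect can now be read on its own, which compound 1 could not offer with its second difference. The other change, hydrogen in place of methyl on a saturated chain carbon bound to an oxygen next to a carbonyl group, gives a 1.9-fold lower number from compound 1 to compound 3 (0.29 log units; within the scatter) and so makes no clear difference while the aromatic methyl is present. Nothing measured here offers a reason for either step.

The compounds shown carry only hydrogen or methyl on this aromatic carbon, so it stays open how a chlorine or a methoxy group there would read. Going by these compounds, it also stays open how a longer chain, such as propyl, would read in place of the methyl on the oxygen.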